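This account rests on a few compounds, and the source may have more. Where it says the series, first, only, none or still open, it means among the compounds named here.

Measured compounds:
- Compound 1, `O=C(Nc1cccc(-c2oc3cc(-c4ccc(F)cc4)ccc3c(=O)c2O)c1)c1ccc(Cl)cc1`, gives 10800 nM in a functional assay on A549 cells (Homo sapiens) for antiproliferative activity, read by CCK-8 assay, with a stated time of 72 h; a higher number here means a weaker inhibitor, a lower number a stronger inhibitor.
- Compound 2, `O=C(Nc1cccc(-c2oc3cc(-c4ccc(F)cc4)ccc3c(=O)c2O)c1)c1ccc(Br)cc1F`, gives 46100 nM in this assay.
- Compound 3, `Cc1cc(C(=O)Nc2cccc(-c3oc4cc(-c5ccc(F)cc5)ccc4c(=O)c3O)c2)ccc1F`, gives 11500 nM in this assay.

All three share one core and differ only in the aryl group attached to the carbonyl carbon of the amide. Compound 3 stands second highest of the three numbers: its value and that of compound 1 lie within the scatter of each other, as a 1.1-fold higher number from compound 1 to compound 3 (0.03 log units; within the scatter) shows, while compound 2 sits apart, as seen in a 4.0-fold lower number from compound 2 to compound 3 (0.60 log units; beyond the scatter) and a 4.3-fold higher number from compound 1 to compound 2 (0.63 log units; beyond the scatter).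

Compound 4, `O=C(Nc1cccc(-c2oc3cc(-c4ccc(F)cc4)ccc3c(=O)c2O)c1)c1ccc(Cl)nc1`, is the next step from compound 3. The change is 6-chloropyridin-3-yl in place of 4-fluoro-3-methylphenyl on a carbonyl carbon. The measured steps at this same position were either within the scatter or modest in size, so only a small shift is expected here, with no clear direction given by the data. Compound 4 is therefore estimated at 14000 nM, with a range from 5000 nM to 45000 nM, which means an expected step of a 1.2-fold higher number from compound 3 to compound 4 (0.09 log units; within the scatter).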

Compound 4, half-maximal inhibitory concentration: 3580 nM
Estimate against measurement, compound 4: 3.9-fold (0.59 log units) above; the measured number lies below the stated range.
By their numbers in this assay, from the lowest: compound 4; then compounds 1 and 3 (each within the scatter of the next); then compound 2.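

Among these compounds, compound 4 is the first change at this position to move the number down beyond the scatter, with a 3.2-fold lower number from compound 3 to compound 4 (0.51 log units; beyond the scatter) and a 3.0-fold lower number from compound 1 to compound 4 (0.48 log units; beyond the scatter), so the aryl group on the amide carbonyl can strengthen the result in this assay as well as weaken it. The second of those steps is the closest comparison, since both groups carry a chlorine and the 6-chloropyridin-3-yl ring adds a ring nitrogen, while a 13-fold lower number from compound 2 to compound 4 (1.11 log units; beyond the scatter) shows that the choice of group here can produce a large step. No independent measurement bears on what lies behind these shifts.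

The compounds shown leave open whether the ring nitrogen would give the same step without the chlorine, as in an unsubstituted pyridine ring. They also leave open how an amine or a methoxy group on that ring, or a saturated piperidine ring in its place, would read.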